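Microsomal stability: from compound 1 to compound 4

The source may report more compounds than this note shows. Statements on the series, on what has been measured and on what is new or still open speak of the compounds shown alone.

Measured so far:
- Compound 1 `CS(=O)(=O)c1cc(F)cc(-c2cc(N3CC(N)C(c4cc(F)c(F)cc4F)C3)ncn2)c1`: in an in vitro ADME assay on microsomes from liver (Homo sapiens) for metabolic stability (on this read-out higher numbers stand for a longer-lived compound and lower numbers for a shorter-lived compound), compound 1 gives > 3 h, a limit of the assay and not a number.
- Compound 2 `NC1CN(c2cc(-c3ccsc3)ncn2)CC1c1cc(F)c(F)cc1Cl`: in this assay compound 2 gives > 3 h, again only a limit.
- Compound 3 `COc1ccc(-c2cnc(N3CC(N)C(c4ccc(Cl)cc4Cl)C3)nc2)cc1`: in this assay compound 3 gives > 3 h, also a limit.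

Going by the values given here, compound 1 therefore stands at the limit of > 3 h in this assay, at which 3 of the 3 values shown sit; every measured value sits there, so no step between measured compounds can be read. Compound 4 `CS(=O)(=O)c1cccc(-c2cc(N3CC(N)C(c4cc(F)c(F)cc4F)C3)ncn2)c1` differs from compound 1 by hydrogen in place of fluoro on an aromatic carbon. The expected step in this assay is a step that the limit leaves unreadable from compound 1 to compound 4, that is, nothing beyond the usual scatter. Compound 4 is expected to give about 3.5 h, within 1.5 h to 8 h, most likely reported once more as a limit.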

Compound 4, half-life: > 3 h
Compound 4 was reported as a limit (the forecaster's own chance of this, stated with the estimate: 70%); the middle value is on the limit's open side.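

Going by these compounds alone, compound 1 and compound 4 both stop at a limit in this assay, so no step between them can be read: the limit of > 3 h in this assay, at which 4 of the 4 values shown sit. The compounds shown leave open how long any of them actually lasts, and whether hydrogen in place of fluoro changes the half-life at all.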